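Swapping a small chain for an acetylcyclohexyl group at the ring nitrogen

The source may report more compounds than this note shows. Statements on the series, on what has been measured and on what is new or still open speak of the compounds shown alone.

Compound 1, `CC(C)c1onc(-c2c(Cl)cccc2Cl)c1COc1ccc(-c2nc3ccc(C(=O)O)cc3n2CC2CCCCC2)c(F)c1`, 840 nM
Compound 2, `CCn1c(-c2ccc(OCc3c(-c4c(Cl)cccc4Cl)noc3C(C)C)cc2)nc2ccc(C(=O)O)cc21`, 5760 nM
Compound 3, `CCC(CC)n1c(-c2ccc(OCc3c(-c4c(Cl)cccc4Cl)noc3C(C)C)cc2Cl)nc2ccc(C(=O)O)cc21`, 1010 nM

All three were tested in an assay on HEK-293T cells for antagonist activity at vitamin D3 receptor (Homo sapiens), read by a luciferase reporter, with a stated time of 24 h; a lower number here means a stronger inhibitor, a higher number a weaker inhibitor. Compound 2 gives the highest number of the three, so it is the weakest inhibitor here; compound 3 lies nearest to it, and compound 1 furthest, both gaps beyond the usual scatter. Compound 1 and compound 3 each differ from compound 2 in more than one place, so their values show only that other substituents on the same core can go with lower numbers.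

Compound 4, `CC(=O)C1CCC(Cn2c(-c3ccc(OCc4c(-c5c(Cl)cccc5Cl)noc4C(C)C)cc3)nc3ccc(C(=O)O)cc32)CC1`, has not yet been measured. It differs from compound 2 in one place: 4-acetylcyclohexyl in place of methyl on a saturated chain carbon bound to an aromatic nitrogen. Among the compounds with values here, no single-change step between measured compounds is available to calibrate this, so the expectation rests on compound 1 with 840 nM and compound 3 with 1010 nM, which suggest that changing this part of the molecule away from a short chain lowers the number.

Compound 4 is therefore expected to be a stronger inhibitor than compound 2, with a step of a 4.4-fold lower number from compound 2 to compound 4 (0.65 log units; beyond the scatter) that should exceed the scatter. The estimate for compound 4 is 1300 nM, within a range from 400 nM to 4500 nM.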

Compound 4, half-maximal inhibitory concentration: > 10000 nM
Compound 4 was reported as a limit; the forecaster's own chance of this, stated with the estimate: 5%; middle value at least 7.6-fold (0.88 log units) away from the limit.
By their numbers in this assay, from the lowest: compounds 1 and 3 (each within the scatter of the next); then compound 2. At a limit, above all of these: compound 4.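

In this assay compound 4 is reported only as a limit: the limit of > 10000 nM in this assay, at which 1 of the 4 values shown sits. Within the data shown here, this is the first change at this place that can be read on its own: 4-acetylcyclohexyl in place of methyl gives an at least 1.7-fold higher number from compound 2 to compound 4 (0.23 log units; that floor lies within the scatter), so the size of the step has only a floor, and that floor does not separate the two compounds. Even so, this larger group did not bring the lower number that compounds 1 and 3 had suggested, and those two differ from compound 2 in more than one place, so their values cannot be credited to this position alone.

The compounds shown do not separate the part played by the cyclohexyl ring from that of its acetyl group. As far as these compounds go, how a 4-aminocyclohexyl group, a 4-carboxycyclohexyl group or a longer chain such as butyl would read at this place on the same core also stays open.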